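Dichloro core on the benzyl chloride series: compound 4

A few compounds are considered here, and "the series" means these few. Any claim that something is new, unique, unknown or untested is made for them only; others in the source may bear on it.

Compound 1 `ClCc1ccc(Cn2cnc3c(Cl)ncnc32)cc1` is the reference point. Among the compounds with values here, in a functional assay on HCT-116 cells (Homo sapiens) for cytotoxicity, read by sulforhodamine B assay, with a stated time of 48 h (a lower number here means that less compound is tolerated, a higher number that more compound is tolerated), compound 1 gives 25100 nM, the highest of the three numbers measured so far. Compound 2 `ClCc1cccc(Cn2cnc3c(Cl)nc(Cl)nc32)c1` gives 5880 nM in this assay, and compound 3 `ClCc1cccc(Cn2cnc3nc(Cl)nc(Cl)c32)c1` gives 4460 nM; both of these sit beyond the scatter below compound 1, compound 2 by the smaller margin and compound 3 by the larger. Within the data shown here, no pair among the measured compounds differs in a single place, so no direct step is available.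

Compound 4 `ClCc1ccc(Cn2cnc3c(Cl)nc(Cl)nc32)cc1` is not yet measured. It differs from compound 1 as follows: chloro in place of hydrogen on an aromatic carbon. Compounds 2 and 3 carry their chloro groups on a core of the same kind, yet they also differ from compound 4 elsewhere, so their lower numbers only hint at the direction.

The expected step from compound 1 to compound 4 in this assay is a lower number, a 3.1-fold lower number from compound 1 to compound 4 (0.50 log units; beyond the scatter), short of what compound 2 shows at 5880 nM against compound 1. Compound 4 is therefore estimated at 8000 nM in this assay, with a range from 3000 nM to 20000 nM.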

Compound 4, concentration lethal to 50% of the cells: 7590 nM
The estimate for compound 4 lay 1.1-fold (0.02 log units) above the measured number, and the stated range covers the measured number.
By their numbers in this assay, from the lowest: compounds 3, 2 and 4 (each within the scatter of the next); then compound 1.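

Chloro in place of hydrogen on an aromatic carbon, at the place between two ring nitrogen atoms, gives the first single-place comparison in the series: in this assay the step is a 3.3-fold lower number from compound 1 to compound 4 (0.52 log units; beyond the scatter), which is beyond the usual scatter and modest in size. This place on the six-membered aromatic ring with 2 nitrogen is therefore not silent in this read-out, since adding one chlorine atom means that less compound is tolerated. Nothing at hand bears on why the number moves, so the step stands as an observation only.

From the compounds shown here alone, it remains open whether another group at this same place, such as an amine, a methoxy group or a methyl group, would move the number in the same direction or by a similar amount. Going by these compounds, with a single step at a single place, it also remains open whether the effect of this chloro carries over to other members, or whether it depends on the rest of the structure of compound 1.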